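Swapping 3-fluorophenyl for 4-methylphenyl on a second core

This account rests on a few compounds, and the source may have more. Where it says the series, first, only, none or still open, it means among the compounds named here.

Measured in a functional assay on MCF7 cells (Homo sapiens) for cytotoxicity, read by MTT assay, with a stated time of 72 h; a higher number here means a weaker inhibitor, a lower number a stronger inhibitor:
compound 1 `CNC(=O)c1cc(Oc2ccc(NC(=O)c3nn(-c4cccc(F)c4)c(=O)cc3C)cc2F)ccn1` gives 6410 nM
compound 2 `CNC(=O)c1cc(Oc2ccc(NC(=O)c3nn(-c4ccc(C)cc4)c(=O)cc3C)cc2F)ccn1` gives 8380 nM
compound 3 `Cc1cc(=O)n(-c2cccc(F)c2)nc1C(=O)Nc1ccc(Oc2ncnc3ccsc23)c(F)c1` gives 9050 nM

The change from compound 1 to compound 2 is 4-methylphenyl in place of 3-fluorophenyl on an aromatic nitrogen; its step is a 1.3-fold higher number from compound 1 to compound 2 (0.12 log units; within the scatter). Compounds 1 and 3 differ in their cores by a group of 9 heavy atoms (6 carbon, 2 nitrogen, 1 sulfur; one five-membered aromatic ring with 1 hetero atom, one six-membered aromatic ring with 2 hetero atoms) in place of a group of 10 heavy atoms (7 carbon, 2 nitrogen, 1 oxygen; one six-membered aromatic ring with 1 hetero atom), on an oxygen on an aromatic ring, with a step of a 1.4-fold higher number from compound 1 to compound 3 (0.15 log units; within the scatter). Compound 4 `Cc1ccc(-n2nc(C(=O)Nc3ccc(Oc4ncnc5ccsc45)c(F)c3)c(C)cc2=O)cc1` is not yet measured; it differs from compound 3 by 4-methylphenyl in place of 3-fluorophenyl on an aromatic nitrogen, the same change as from compound 1 to compound 2, at a place described in the same words. Among the compounds with values here, the step for compound 4 is expected to be a 1.3-fold higher number from compound 3 to compound 4 (0.10 log units; within the scatter), resting on the single earlier instance a 1.3-fold higher number from compound 1 to compound 2 (0.12 log units; within the scatter), which stays within the scatter; with only one precedent the expectation is uncertain. Compound 4 is estimated at 11500 nM in this assay, between 6500 nM and 21000 nM.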

Compound 4, half-maximal inhibitory concentration: 7250 nM
For compound 4 the middle estimate is 1.6-fold (0.20 log units) above the measured one; low and high end bracket the measured number.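

In this assay, the swap to 4-methylphenyl on the second core gives a 1.2-fold lower number from compound 3 to compound 4 (0.10 log units; within the scatter), and the step agrees with its earlier instance: the same change on two cores in this assay, a 1.3-fold higher number (0.12 log units; within the scatter) from compound 1 to compound 2 and a 1.2-fold lower number (0.10 log units; within the scatter) from compound 3 to compound 4, 1.6-fold (0.21 log units) apart, within the scatter of two such steps. The core exchange, read between the two 4-methylphenyl compounds, gives a 1.2-fold lower number from compound 2 to compound 4 (0.06 log units; within the scatter), and it also agrees with its earlier instance: the same change on two cores in this assay, a 1.4-fold higher number (0.15 log units; within the scatter) from compound 1 to compound 3 and a 1.2-fold lower number (0.06 log units; within the scatter) from compound 2 to compound 4, 1.6-fold (0.21 log units) apart, within the scatter of two such steps. In these four compounds, neither change can be told apart from one core or substituent context to the other, but with every step within the scatter this shows no direction for either change and does not show that a larger effect would carry across cores.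

On these data alone, whether the cores would still agree with an amine or a carboxylic acid on the aromatic ring in place of 3-fluorophenyl or 4-methylphenyl stays open. Also open, as far as these compounds go, is whether any change at this position gives a step beyond the scatter in this assay.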